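Compound 1 to Compound 3: A Smaller Aryl Group

The compounds below may be only part of what the source reports. "The series", "measured", "known", "first", "only" and "open" are said of these compounds alone.

Compound 1 `COc1ccc(CNC(=O)c2nc(-c3ccc(F)cc3)n(CC[C@@H](O)C[C@@H](O)CC(=O)O)c2C2CC2)cc1F`: 0.2 nM
Compound 2 `Cc1ccc(CNC(=O)c2nn(-c3ccc(F)cc3)c(CC[C@@H](O)C[C@@H](O)CC(=O)O)c2C(C)C)cc1`: 0.9 nM

In a functional assay on cells (Hepatocyte, Rattus norvegicus) for inhibition, read by scintillation counting, with a stated time of 4 h (a lower number here means a stronger inhibitor, a higher number a weaker inhibitor), compound 1 gives 0.2 nM, the lowest of the two numbers, while compound 2 gives 0.9 nM, a higher number that lies beyond the scatter. Compound 3 `COc1cccc(CNC(=O)c2nc(-c3ccc(F)cc3)n(CC[C@@H](O)C[C@@H](O)CC(=O)O)c2C2CC2)c1` differs from compound 1 in one place: 3-methoxyphenyl in place of 3-fluoro-4-methoxyphenyl on a saturated chain carbon bound to an amide-type nitrogen. Within the data shown here, no measured pair carries this change, so its effect has to be estimated from compound 1 alone. The step from compound 1 to compound 3 in this assay is expected to be a modest rise, a 3.0-fold higher number from compound 1 to compound 3 (0.48 log units; beyond the scatter). Compound 3 is therefore expected to give about 0.6 nM in this assay, within a range from 0.15 nM to 2.5 nM.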

Compound 3, half-maximal inhibitory concentration: 0.2 nM
Compound 3: middle estimate off by 3.0-fold (0.48 log units), on the high side, and the stated range covers the measured number.
By their numbers in this assay, from the lowest: compounds 1 and 3 (each within the scatter of the next); then compound 2.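

Putting 3-methoxyphenyl in place of 3-fluoro-4-methoxyphenyl on a saturated chain carbon bound to an amide-type nitrogen gives, in this assay, no change at the digits printed from compound 1 to compound 3 (within the scatter). Among these compounds, this is the first single-place comparison, and it shows that this aryl group can be exchanged with the rest of the molecule held constant while the number stays within the scatter. Nothing available explains this result.

The compounds shown leave open how a 3-hydroxyphenyl or 3-chlorophenyl group would read at this place. They also leave open whether the same exchange would read alike on the core of compound 2.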